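A few compounds are considered here, and "the series" means these few. Any claim that something is new, unique, unknown or untested is made for them only; others in the source may bear on it.

Working notes on the cyclic substituent on the ring nitrogen of the shared core.

Compound 1 `Nc1ncnc2c1c(Oc1cccc(C(F)(F)F)c1)nn2[C@H]1C[C@H](O)C1` gives 1.25 h in an ADME assay on microsomes from liver (Homo sapiens) for metabolic stability, read by LC-MS, using NADPH, with a stated time of 10 min, tested at 10 uM; a higher number here means that the compound lasts longer, a lower number that the compound disappears faster. Compound 3 `Nc1ncnc2c1c(Oc1cc(C(F)(F)F)ccn1)nn2[C@H]1C[C@H](F)C1` gives 2.03 h in this assay, and its gap to compound 1 lies within the scatter, so the two are not distinguished on these numbers. Compound 2 `Nc1ncnc2c1c(Oc1cc(C(F)(F)F)ccn1)nn2[C@H]1CC[C@@H](N)CC1` reaches only a limit of the assay, > 2.41 h, in this assay. Among the measured compounds shown here, the one step that crosses from an amine-bearing saturated ring to the fluorocyclobutyl is an at least 1.1-fold lower number from compound 2 to compound 3 (0.07 log units; that floor lies within the scatter), and its floor sits within the scatter.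

Compound 4 `Nc1ncnc2c1c(Oc1cc(C(F)(F)F)ccn1)nn2[C@@H]1CC[C@H](N)C1` carries the change (3-aminocyclopentyl in place of 3-fluorocyclobutyl on an aromatic nitrogen). For the measured compounds named here, the step from compound 2 to compound 3 is the only measured guide, and it allows no step beyond the scatter in either direction; the range is kept wide because the limit of > 2.41 h in this assay, at which 1 of the 3 values shown sits, means the amine-bearing analogue gave no number. Compound 4 is therefore expected to show a 1.1-fold higher number from compound 3 to compound 4 (0.05 log units; within the scatter) in this assay, with the estimate 2.3 h for compound 4 lying between 1.3 h and 4.5 h.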

Compound 4, half-life: > 2.41 h
Compound 4: a limit, no number; the forecaster's own chance of this, stated with the estimate: 40%; middle value at least 1.0-fold (0.02 log units) away from the limit.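

In this assay, compound 4 shows that a second amine-bearing saturated ring, 3-aminocyclopentyl, ends at a limit of the assay as 4-aminocyclohexyl does in compound 2, so that outcome is not confined to a single ring size. Going by these compounds, the swap of the 3-fluorocyclobutyl gives an at least 1.1-fold higher number from compound 3 to compound 4 (0.07 log units; that floor lies within the scatter), so the floor does not separate the two groups, and the true size of the step remains unknown. The step from compound 2 to compound 4 cannot be read, as both values are limits: the limit of > 2.41 h in this assay, at which 2 of the 4 values shown sit.

On these data alone, this swap alters the ring and its substituent together, so the share of each in the outcome stays open. Also open, as far as these compounds go, is how an amide or a carboxylic acid on the same cyclopentyl ring would behave in this assay.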